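Shortening the aryl chain: from propyl to methyl

This account rests on a few compounds, and the source may have more. Where it says the series, first, only, none or still open, it means among the compounds named here.

The shared core of compound 1 `CCCc1ccc(NC2=CC(=O)c3nc4n(c3C2=O)[C@H]2OC[C@@H](O)[C@H]2OC4)cc1` carries a 4-propylphenyl amino group on a double-bonded ring carbon. In a functional assay on ECa-109 cells for inhibition, with ECa-109 cell line (Homo sapiens) as the target, read by sulforhodamine B assay (a lower number here means a stronger inhibitor, a higher number a weaker inhibitor), compound 1 gives > 4000 nM, which is a limit of the assay rather than a number, the limit recorded in the limit of > 4000 nM in this assay, at which 1 of the 3 values shown sits. Compound 2 `O=C1C(Nc2ccc(Br)cc2)=CC(=O)c2c1nc1n2[C@H]2OC[C@@H](O)[C@H]2OC1`, bearing (4-bromophenyl)amino in the same place, gives 1980 nM in this assay. Compound 3 `O=C1C(N2CCCC2)=CC(=O)c2c1nc1n2[C@H]2OC[C@@H](O)[C@H]2OC1` carries pyrrolidin-1-yl instead. In this assay compound 3 gives > 16000 nM, again a limit, the one noted in the limit of > 16000 nM in this assay, at which 1 of the 3 values shown sits. Among the measured compounds shown here, the only measured step, an at least 8.0-fold higher number from compound 2 to compound 3 (0.90 log units; beyond the scatter), shows that the arylamino group matters, but it does not touch the chain on the phenyl ring and so bears only loosely on the present change.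

Compound 4 `Cc1ccc(NC2=CC(=O)c3nc4n(c3C2=O)[C@H]2OC[C@@H](O)[C@H]2OC4)cc1` differs from compound 1 by hydrogen in place of ethyl on a saturated chain carbon bound to an aromatic carbon. For the measured compounds named here, no measured pair alters this chain, so the direction of the step is open; still, compound 2 at 1980 nM shows that a different group on the phenyl ring can sit within the measurable range, whereas compound 1 does not. One therefore expects a modest step, an at least 1.3-fold lower number from compound 1 to compound 4 (0.12 log units; that floor lies within the scatter), toward a lower number. Compound 4 is estimated at 3000 nM, within 800 nM to 12000 nM, with a real chance that only a limit is reported.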

Compound 4, half-maximal inhibitory concentration: 3480 nM
For compound 4 the middle estimate is 1.2-fold (0.06 log units) below the measured one, and the stated range covers the measured number.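

Hydrogen in place of ethyl on a saturated chain carbon bound to an aromatic carbon gives an at least 1.1-fold lower number from compound 1 to compound 4 (0.06 log units; that floor lies within the scatter), the only listed step that touches the chain on the phenyl ring. With the 4-methylphenyl group, compound 4 has a measured number in this assay rather than a limit, so an alkyl chain at this place can sit within the measurable range, as the (4-bromophenyl)amino group of compound 2 also does. Even so, the step shows only that shortening propyl to methyl does not raise the number, and its true size stays unknown because compound 1 is recorded only as a limit: the limit of > 4000 nM in this assay, at which 1 of the 4 values shown sits.

The compounds shown therefore leave open whether chain length has any real effect on the number here, since no chain with a measured value can be set against the methyl of compound 4. They also leave open how an ethyl or butyl chain, a methoxy group or a carboxylic acid in the same place would read in this assay, and whether any of these would go beyond the scatter.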